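The source may hold more compounds than are shown below. What is called first, only, known or untested is meant among the compounds shown, and "the series" means these compounds.

Measured in a functional assay on HL-60 cells (Homo sapiens) for antiproliferative activity, read by MTT assay; on this read-out higher numbers stand for weaker inhibition and lower numbers for stronger inhibition:
- Compound 1 `COc1ccc(/C=N/NC(=O)c2cn(C3CC3)c3cc(N/N=C/c4ccc(OC)c(O)c4)c(F)cc3c2=O)cc1O`: <= 25000 nM
- Compound 2 `O=C(N/N=C/c1ccc(F)cc1)c1cn(C2CC2)c2cc(N/N=C/c3ccc(F)cc3)c(F)cc2c1=O`: <= 25000 nM

Compound 1 gives only a limit, not a number. As far as these compounds go, compound 2 also gives only a limit, <= 25000 nM, so its exact standing in this assay is unknown. The step to compound 3 `O=C(N/N=C/c1ccc(F)cc1)c1cn(C2CC2)c2cc(N3CCNCC3)c(F)cc2c1=O` alters one place, on an aromatic carbon ortho to a fluoro group, where piperazin-1-yl enters: a group of 6 heavy atoms (4 carbon, 2 nitrogen; one six-membered non-aromatic ring with 2 hetero atoms) in place of a group of 10 heavy atoms (7 carbon, 2 nitrogen, 1 fluorine; one six-membered aromatic ring of carbon only), on an aromatic carbon. With only limits to compare, no change beyond the usual scatter is expected in either direction, and the estimated step is a step that the limit leaves unreadable from compound 2 to compound 3. Compound 3 is expected at 20000 nM, with an estimated range of 6000 nM to 60000 nM.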

Compound 3, half-maximal inhibitory concentration: <= 25000 nM
Compound 3 gave a limit, no number; the forecaster's own chance of this, stated with the estimate: 40%; the middle value does not contradict the limit.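

For the compounds shown here, compound 2 and compound 3 both give only a limit in this assay, so no step between them can be read: the limit of <= 25000 nM in this assay, at which 3 of the 3 values shown sit. How strongly each compound shown inhibits, and whether piperazin-1-yl changes that, stays open.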